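Adding a Bromine to the Anilide of Compound 1

The source may report more compounds than this note shows. Statements on the series, on what has been measured and on what is new or still open speak of the compounds shown alone.

Among the measured compounds shown here, compound 1 `COc1ccc2nc(C)cc(OCC(=O)Nc3ccccc3)c2c1` is the only member of this set with a numerical value in an ADME assay on HepG2 cells (Homo sapiens) for cytotoxicity, read by trypan blue exclusion, with a stated time of 48 h, in the presence of a further agent that is not named here (a higher number here means that more compound is tolerated, a lower number that less compound is tolerated), where it gives 118000 nM. Compound 2 `COc1ccccc1NC(=O)COc1cc(C)nc2ccc(C(F)(F)F)cc12` reaches only a limit of the assay, > 128000 nM. Compound 3 `COc1ccc(NC(=O)COc2cc(C)nc3ccc(OC)cc23)c(OC)c1` likewise reaches only a limit of the assay, > 131000 nM. Compound 4 `COc1ccc2nc(C)cc(OCC(=O)Nc3ccc(Br)cc3)c2c1` differs from compound 1 by bromo in place of hydrogen on an aromatic carbon. For the measured compounds named here, no two measured compounds differ in just one place, so no measured step size exists to lean on. The expected step of a 1.1-fold lower number from compound 1 to compound 4 (0.03 log units; within the scatter) is judged to stay within the usual scatter, with no clear direction. The estimate for compound 4 is therefore 110000 nM, with a range from 55000 nM to 200000 nM.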

Compound 4, half-maximal cytotoxic concentration: > 125000 nM
Compound 4: only a limit was reported; the forecaster's own chance of this, stated with the estimate: 35%; middle value at least 1.1-fold (0.05 log units) away from the limit.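

Going from phenyl to 4-bromophenyl on the anilide of the shared core gives an at least 1.0-fold higher number from compound 1 to compound 4 (0.02 log units; that floor lies within the scatter) in this assay. Among the compounds shown here, this is the only single change that can be read here, and it shows that bromo at this place, para to a large group, brings no sign of less compound being tolerated. For compound 4 the reading is a limit of the assay, not a number: the limit of > 125000 nM in this assay, at which 1 of the 4 values shown sits.

On these data alone, how far the true value of compound 4 lies from that of compound 1 remains open. So does whether an amine or a carboxylic acid at this same place would leave the tolerated concentration unchanged.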